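The source may report more compounds than this note shows. Statements on the series, on what has been measured and on what is new or still open speak of the compounds shown alone.

Compound 1 `Nc1ncnc2c1c(-c1cnc3[nH]ccc3c1)nn2CCCCCCCCC(=O)NO` and compound 2 `Nc1ncnc2c1c(-c1cnc3[nH]ccc3c1)nn2CCCCCCCCCC(=O)NO` share one core and differ only in the chain. In a functional assay on Hep 3B2 cells (Homo sapiens) for inhibition, read by MTT assay, with a stated time of 72 h (on this read-out higher numbers stand for weaker inhibition and lower numbers for stronger inhibition), compound 1 gives 8390 nM, while compound 2 gives 17200 nM in this assay. The change between them, ((hydroxycarbamoyl)methyl in place of hydroxycarbamoyl on a saturated chain carbon, eight bonds along the chain from an aromatic nitrogen), produced a 2.1-fold higher number from compound 1 to compound 2 (0.31 log units; beyond the scatter). Compound 3 `Nc1nc2cc(-c3nn(CCCCC(=O)NO)c4ncnc(N)c34)ccc2o1` carries a different core; how that core differs from the core of compound 1 is not broken down here, and in this assay compound 3 gives 33700 nM. Compound 4 `Nc1nc2cc(-c3nn(CCCCCC(=O)NO)c4ncnc(N)c34)ccc2o1` differs from compound 3 by (hydroxycarbamoyl)methyl in place of hydroxycarbamoyl on a saturated chain carbon, four bonds along the chain from an aromatic nitrogen. This is the same kind of change as that from compound 1 to compound 2, but it sits four bonds along the chain from an aromatic nitrogen rather than eight. Because a 2.1-fold higher number from compound 1 to compound 2 (0.31 log units; beyond the scatter) was modest, compound 4 is expected to show a comparable step, a 1.6-fold higher number from compound 3 to compound 4 (0.21 log units; within the scatter), in this assay. Compound 4 is therefore estimated at 55000 nM, between 20000 nM and 150000 nM, in this assay.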

Compound 4, half-maximal inhibitory concentration: 34200 nM
Estimate against measurement, compound 4: 1.6-fold (0.21 log units) above, within the range that was stated.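

In this assay the change from hydroxycarbamoyl to (hydroxycarbamoyl)methyl gives a 1.0-fold higher number from compound 3 to compound 4 (0.01 log units; within the scatter) on the core of compound 3. Set beside the same change on the core of compound 1, the two steps cannot be told apart: the same change on two cores in this assay, a 2.1-fold higher number (0.31 log units; beyond the scatter) from compound 1 to compound 2 and a 1.0-fold higher number (0.01 log units; within the scatter) from compound 3 to compound 4, 2.0-fold (0.31 log units) apart, within the scatter of two such steps. This shows that the result on one core is compatible with that on the other, but it does not show that the change carries over unaltered, as each core offers a single pair and the change sits at a different place along the chain in each.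

As far as these compounds go, what a longer chain would do on the core of compound 3 remains open. So does the effect of a carboxylic acid in place of the hydroxycarbamoyl group on either core.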